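Notes on varying the aryl group of the shared core

The source may hold more compounds than are shown below. What is called first, only, known or untested is meant among the compounds shown, and "the series" means these compounds.

Measured so far in a functional assay on HT-29 cells (Homo sapiens) for inhibition, read by sulforhodamine B assay, with a stated time of 48 h, tested at 10 uM; on this read-out lower numbers stand for less inhibition and higher numbers for more inhibition at the one concentration tested (going by the name of the read-out):
compound 1 `Brc1cn2ccnc2c(-c2ccc3ncn(C4CCCCC4)c3c2)n1` gives 5.21%
compound 2 `c1ccc(-c2cn3ccnc3c(-c3ccc4ncn(C5CCCCC5)c4c3)n2)cc1` gives 48.3%
compound 3 `c1ccc2c(-c3cn4ccnc4c(-c4ccc5ncn(C6CCCCC6)c5c4)n3)cccc2c1` gives 4.11%

Compound 2 holds the highest of the three numbers. The step of a number 43.1 percentage points higher from compound 1 to compound 2 (beyond the scatter) and the step of a number 44.2 percentage points lower from compound 2 to compound 3 (beyond the scatter) both lie beyond the scatter, whereas compound 1 and compound 3 sit within the scatter of each other, as a number 1.1 percentage points lower from compound 1 to compound 3 (within the scatter) shows. Compound 4 is `CC(=O)c1ccc(-c2cn3ccnc3c(-c3ccc4ncn(C5CCCCC5)c4c3)n2)cc1`; it differs from compound 2 thus: acetyl in place of hydrogen on an aromatic carbon. For the measured compounds named here, no measured step covers an acetyl. Going by the values given here, the steps that bear on the same aromatic carbon, a number 43.1 percentage points higher from compound 1 to compound 2 (beyond the scatter) and a number 44.2 percentage points lower from compound 2 to compound 3 (beyond the scatter), were large and ran in opposite directions, so the group at that carbon clearly matters, yet nothing here tells which way adding acetyl to the phenyl will move the number. The estimated step for compound 4 is therefore a number 8.3 percentage points lower from compound 2 to compound 4 (within the scatter), that is, no clear change beyond the scatter but with a wide range in this assay. Compound 4 is estimated at 40%, between 10% and 70%.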

Compound 4, a percentage reported as inhibition, at one concentration (the size of the read-out at that concentration, not a potency): 9.2%
Estimate against measurement, compound 4: 30.8 percentage points above; measured number below the stated range.
By their numbers in this assay, from the lowest: compounds 3, 1 and 4 (each within the scatter of the next); then compound 2.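

In this assay the step of a number 39.1 percentage points lower from compound 2 to compound 4 (beyond the scatter) shows that the number depends not only on the group attached to the core but also on what the phenyl ring carries, here acetyl para to a large group. The steps of a number 5.1 percentage points higher from compound 3 to compound 4 (within the scatter) and a number 4 percentage points higher from compound 1 to compound 4 (within the scatter) show no clear difference among these three compounds, so of the four compounds only compound 2 stands apart. Nothing available gives a reason for the loss seen with acetyl.

Going by these compounds, whether this loss is particular to acetyl or would follow any group at that place on the phenyl ring stays open, as does the outcome with an amine, a carboxylic acid or a methoxy group there. With a single concentration per compound, the numbers also leave potency across the series open.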